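Series notes: tert-butyl replacing cyclopropyl on the shared core

This account rests on a few compounds, and the source may have more. Where it says the series, first, only, none or still open, it means among the compounds named here.

Measured so far, in an assay on blood for inhibition of C-X-C chemokine receptor type 3 (Homo sapiens), with a stated time of 30 min; on this read-out lower numbers stand for stronger inhibition and higher numbers for weaker inhibition:
- compound 1 `CCOc1ncc(-c2nc(C(F)(F)F)sc2N2CCN(C(=O)Cn3nc(C)nc3C)[C@H](C)C2)cn1`: 364 nM
- compound 2 `Cc1nc(C)n(CC(=O)N2CCN(c3sc(C(F)(F)F)nc3-c3cnc(OC(C)C)nc3)C[C@H]2C)n1`: 216 nM
- compound 3 `Cc1nc(C)n(CC(=O)N2CCN(c3sc(C(F)(F)F)nc3-c3cnc(C4CC4)nc3)C[C@H]2C)n1`: 674 nM

Compound 3 gives the highest number of the three in this assay. Its gap to compound 1 is within the scatter, a 1.9-fold higher number from compound 1 to compound 3 (0.27 log units; within the scatter); its gap to compound 2 is beyond it, a 3.1-fold higher number from compound 2 to compound 3 (0.49 log units; beyond the scatter).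

Compound 4 `Cc1nc(C)n(CC(=O)N2CCN(c3sc(C(F)(F)F)nc3-c3cnc(C(C)(C)C)nc3)C[C@H]2C)n1` differs from compound 3 only at one position: tert-butyl in place of cyclopropyl on an aromatic carbon.

Among the measured compounds shown here, no measured step swaps one carbon-only group for another at that aromatic carbon. The two steps that touch the position, a 1.9-fold higher number from compound 1 to compound 3 (0.27 log units; within the scatter) and a 3.1-fold higher number from compound 2 to compound 3 (0.49 log units; beyond the scatter), each exchange an ether for a ring, so they do not map onto this change. For the measured compounds named here, the one step that merely adds a methyl, a 1.7-fold lower number from compound 1 to compound 2 (0.23 log units; within the scatter), stays within the scatter. On that basis compound 4 is expected to sit near compound 3, with at most a small shift toward a lower number, a 1.3-fold lower number from compound 3 to compound 4 (0.13 log units; within the scatter). The estimate for compound 4 in this assay is 500 nM, with a range from 200 nM to 1300 nM.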

Compound 4, half-maximal inhibitory concentration: 1160 nM
Beside the measured number, compound 4's estimate is 2.3-fold (0.37 log units) below it, and the stated range covers the measured number.
By their numbers in this assay, from the lowest: compounds 2, 1, 3 and 4 (each within the scatter of the next, the first and the last beyond it).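

In this assay, among the compounds shown here, the only step that swaps one carbon-only group for another at this aromatic carbon, a 1.7-fold higher number from compound 3 to compound 4 (0.24 log units; within the scatter), leaves cyclopropyl and tert-butyl unseparated, so opening the ring and adding a carbon give no readable change here. The ether groups are set apart more clearly by tert-butyl than by cyclopropyl: a 3.2-fold higher number from compound 1 to compound 4 (0.50 log units; beyond the scatter) and a 5.4-fold higher number from compound 2 to compound 4 (0.73 log units; beyond the scatter) are both beyond the scatter, whereas only the isopropoxy comparison was beyond it for cyclopropyl. No measurement at hand accounts for this gap between the ether groups and tert-butyl.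

Going by these compounds, whether the oxygen link itself matters remains open. A dimethylamino group or an n-propyl chain at that aromatic carbon would show whether other linking atoms or an unbranched carbon chain fall with the ethers or with tert-butyl.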